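A few compounds are considered here, and "the series" means these few. Any claim that something is new, unique, unknown or untested is made for them only; others in the source may bear on it.

The study measures growth inhibition in a functional assay on T47D cells (Homo sapiens) for cytotoxicity, read by MTT assay, with a stated time of 72 h; a higher number here means a weaker inhibitor of growth, a lower number a stronger inhibitor of growth. Compound 1 `COc1cc(OC)c(/C=C/[S+]([O-])Cc2ccc(OC)c(N)c2)c(OC)c1` gives 60 nM in that setting. Compound 2 `COc1ccc(OC)c(NC(=O)CS(=O)(=O)Cc2ccc(OC)c([N+](=O)[O-])c2)c1` is reported only as a limit of the assay, > 30000 nM. Compound 3 `COc1ccc(CS(=O)(=O)CC(=O)Nc2c(C)cc(C)cc2C)cc1[N+](=O)[O-]` likewise returns only a limit in this assay, > 30000 nM. Compound 3 thus stands at the edge of what the assay can report, and the limit of > 30000 nM in this assay, at which 2 of the 3 values shown sit, is where it and compound 2 both rest, with no number attached to either.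

Compound 4 `COc1ccc(CS(=O)(=O)CC(=O)Nc2c(C)cc(C)cc2C)cc1N` differs from compound 3 in a single place: amino in place of nitro on an aromatic carbon. Going by the values given here, no measured pair in this set isolates that exchange. Compound 1 carries an amino group on a different core and inhibits growth strongly, whereas compound 2 and compound 3 carry nitro and both stop at the limit. The account therefore expects compound 4 to shift toward stronger growth inhibition by an uncertain amount, an at least 2.0-fold lower number from compound 3 to compound 4 (0.30 log units; that floor lies within the scatter), while allowing a real chance that it too comes back as a limit. The estimate for compound 4 in this assay is 15000 nM, between 2000 nM and 30000 nM.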

Compound 4, concentration for 50% growth inhibition: > 30000 nM
Compound 4 gave a limit, no number; the forecaster's own chance of this, stated with the estimate: 50%; middle value at least 2.0-fold (0.30 log units) from the limit.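

In this assay, going by these compounds alone, compound 4 returns > 30000 nM as a limit, not a number, and compound 3 also rests at a limit, so no step between compound 3 and compound 4 can be read: the limit of > 30000 nM in this assay, at which 3 of the 4 values shown sit. The compounds shown leave open whether amino in place of nitro changes growth inhibition on this core at all.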